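Replacing a Hydroxy-Bearing Group with a Plain Alkyl Chain

The source may hold more compounds than are shown below. What is called first, only, known or untested is meant among the compounds shown, and "the series" means these compounds.

Compound 1 `CCCn1c(=O)c2nc([C@H]3CC4C=CC3C4)[nH]c2n(CCC)c1=O` is the tightest binder among the measured compounds: in an assay on cell membranes for binding affinity to adenosine receptor A1 (Cavia porcellus), read by radioligand binding (a lower number here means a stronger inhibitor, a higher number a weaker inhibitor), compound 1 gives 3.4 nM. Compound 2 `CCCn1c(=O)c2nc(-c3nn[nH]n3)[nH]c2n(CCC)c1=O` carries 2H-tetrazol-5-yl on the same aromatic carbon; in this assay compound 2 reaches only > 10000 nM, which is a limit of the assay rather than a number (the limit of > 10000 nM in this assay, at which 1 of the 3 values shown sits). The exchange an at least 2900-fold higher number from compound 1 to compound 2 (3.46 log units; beyond the scatter) is thus a large loss. Compound 3 `CCCn1c(=O)c2nc(C(C)(O)CC)[nH]c2n(CCC)c1=O` carries 1-hydroxy-1-methylpropyl; in this assay compound 3 gives 240 nM, the highest of the two numbers shown, after the step of a 71-fold higher number from compound 1 to compound 3 (1.85 log units; beyond the scatter). Against compound 2, the step of an at least 41-fold lower number from compound 2 to compound 3 (1.61 log units; beyond the scatter) recovers much of the lost ground.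

Compound 4 `CCCn1c(=O)c2nc(C(C)(C)CCC)[nH]c2n(CCC)c1=O` differs from compound 3 by 1,1-dimethylbutyl in place of 1-hydroxy-1-methylpropyl on an aromatic carbon. The step that bears most directly on this change is a 71-fold higher number from compound 1 to compound 3 (1.85 log units; beyond the scatter), where an all-carbon group on that aromatic carbon gave a far lower number than the hydroxy-bearing group; an at least 41-fold lower number from compound 2 to compound 3 (1.61 log units; beyond the scatter) points the same way, from a hetero-rich ring toward a group made mostly of carbon. A fall in this assay beyond the scatter is therefore expected for compound 4, though an open chain is not the bicyclic group of compound 1, so not the whole distance back. Compound 4 is estimated at 40 nM, within a range from 10 nM to 160 nM. That estimate corresponds to an expected step of a 6.0-fold lower number from compound 3 to compound 4 (0.78 log units; beyond the scatter).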

Compound 4, inhibition constant: 25 nM
Compound 4: middle estimate off by 1.6-fold (0.20 log units), on the high side; measured number inside the range.
By their numbers in this assay, from the lowest: compound 1; then compound 4; then compound 3. At a limit, above all of these: compound 2.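

Exchanging 1-hydroxy-1-methylpropyl for 1,1-dimethylbutyl on this aromatic carbon, which removes the hydrogen-bond donor and acceptor of the leaving group and leaves only carbon, gives in this assay a 9.6-fold lower number from compound 3 to compound 4 (0.98 log units; beyond the scatter), the first step shown between two open-chain groups at this position. A group with no ring can therefore reach a number well below that of the hydroxy-bearing group, yet the open chain does not match the group with two five-membered non-aromatic rings, and a 7.4-fold higher number from compound 1 to compound 4 (0.87 log units; beyond the scatter) remains. Against the 2H-tetrazol-5-yl group the change reads as an at least 400-fold lower number from compound 2 to compound 4 (2.60 log units; beyond the scatter), which is only a bound, as the value of compound 2 is a limit and not a number: the limit of > 10000 nM in this assay, at which 1 of the 4 values shown sits.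

Compound 4 differs from compound 3 both in the loss of the hydroxy group and in the size of the chain, and the compounds shown leave open which of the two carries the step; a 1,1-dimethylpropyl group on this carbon would part them. Also open, from the compounds shown here alone, is whether a single ring such as cyclopentyl, or a longer chain, would close the remaining distance to compound 1.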